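The compounds below may be only part of what the source reports. "The series", "measured", "known", "first", "only" and "open" are said of these compounds alone.

Of the compounds shown here, three built on one shared core have been tested in a functional assay on U-266 cells (Homo sapiens) for inhibition, read by MTT assay, with a stated time of 48 h, tested at 0.1 uM; a lower number here means less inhibition, a higher number more inhibition at the concentration tested (going by the name of the read-out). Compound 1 `Cc1nc(-c2ccccc2)sc1CN1C(=O)N(C)c2ccc(-c3c(C)noc3C)cc2C1c1ccccc1` gives 7.19% in this assay. Compound 2 `Cc1noc(C)c1-c1ccc2c(c1)C(c1ccccc1)N(Cc1nc(-c3ccccc3)cs1)C(=O)N2C` carries a different group on the saturated chain carbon: 4-phenyl-1,3-thiazol-2-yl in place of 4-methyl-2-phenyl-1,3-thiazol-5-yl on a saturated chain carbon bound to an amide-type nitrogen in a ring. In this assay compound 2 gives 12.7%, which is a number 5.5 percentage points higher from compound 1 to compound 2 (within the scatter). Compound 3 `Cc1nc(-c2ccc(F)cc2)sc1CN1C(=O)N(C)c2ccc(-c3c(C)noc3C)cc2C1c1ccccc1` is compound 1 with a single extra atom: fluoro in place of hydrogen on an aromatic carbon. In this assay compound 3 gives 10%, a step of a number 2.8 percentage points higher from compound 1 to compound 3 (within the scatter). The unmeasured compound 4 `Cc1noc(C)c1-c1ccc2c(c1)C(c1ccccc1)N(Cc1nc(-c3ccc(F)cc3)cs1)C(=O)N2C` is compound 2 carrying the same change at the same place: fluoro in place of hydrogen on an aromatic carbon. For the measured compounds named here, the expected step is a number 2.3 percentage points higher from compound 2 to compound 4 (within the scatter), because a number 2.8 percentage points higher from compound 1 to compound 3 (within the scatter) was the one earlier example of this change, and the two cores differ only as described. That rests on a single pair, so the expectation is loose. Compound 4 is therefore expected to give an estimated 15% in this assay. Compound 4 is expected to fall between 5% and 26%, a range that reflects the ordinary scatter of single-concentration readings more than any real trend among these compounds.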

Compound 4, a percentage reported as inhibition, at one concentration (the size of the read-out at that concentration, not a potency): 12.6%
Compound 4: middle estimate off by 2.4 percentage points, on the high side; low and high end bracket the measured number.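

In this assay, fluoro in place of hydrogen on the phenyl group of compound 2 gives a number 0.1 percentage points lower from compound 2 to compound 4 (within the scatter), and exchanging the whole group on the saturated chain carbon gives a number 5.4 percentage points higher from compound 1 to compound 4 (within the scatter). Set side by side, the two fluoro steps cannot be told apart: the same change on two cores in this assay, a number 2.8 percentage points higher (within the scatter) from compound 1 to compound 3 and a number 0.1 percentage points lower (within the scatter) from compound 2 to compound 4, 2.9 percentage points apart, within the scatter of two such steps

So the change carries from one core to the other with no visible difference, but this does not show that fluoro raises or lowers the number on either core, since each step is no larger than the ordinary spread of repeated readings, and two pairs read at one concentration say nothing about potency.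

Open, on these data alone, is whether another group at the same place on the phenyl ring, such as chloro, methoxy or an amine, would move the reading beyond the scatter. Also open, as far as these compounds go, is whether a difference between the two cores would appear at a higher concentration, where the readings might be larger.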